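The source may report more compounds than this note shows. Statements on the series, on what has been measured and on what is new or still open speak of the compounds shown alone.

Measured compounds:
compound 1, `CC(=O)N1CCN(c2ccc(Nc3nccc(-c4c[nH]c5cccnc45)n3)cc2)CC1`, 420 nM
compound 2, `CC(=O)N1CCN(c2ccc(Nc3nccc(-c4c[nH]c5ccccc45)n3)cc2)CC1`, 33 nM
compound 3, `CC(=O)N1CCN(c2ccc(Nc3nccc(-c4c[nH]c5ncccc45)n3)cc2)CC1`, < 1 nM

All three share a core and differ only in the bicyclic group attached to it, and they were compared in a functional assay on MV4-11 cells (Homo sapiens) for antiproliferative activity, read by resazurin assay, with a stated time of 72 h; on this read-out higher numbers stand for weaker inhibition of growth and lower numbers for stronger inhibition of growth. For compound 3 the value is a limit of this assay and not a number, as the limit of < 1 nM in this assay, at which 1 of the 3 values shown sits, records. Against compound 1 the two others stand far apart: a 13-fold lower number from compound 1 to compound 2 (1.10 log units; beyond the scatter), and an at least 420-fold lower number from compound 1 to compound 3 (2.62 log units; beyond the scatter). Between the two stronger ones, an at least 33-fold lower number from compound 2 to compound 3 (1.51 log units; beyond the scatter). Compound 3 is therefore the strongest of the three on the numbers shown, every step to it lying beyond the scatter.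

Compound 4, `CC(=O)N1CCN(c2ccc(Nc3nccc(-c4n[nH]c5ccccc45)n3)cc2)CC1`, has not yet been measured in this assay. The change from compound 3 is a group of 9 heavy atoms (7 carbon, 2 nitrogen; one five-membered aromatic ring with 2 hetero atoms, one six-membered aromatic ring of carbon only) in place of a group of 9 heavy atoms (7 carbon, 2 nitrogen; one five-membered aromatic ring with 1 hetero atom, one six-membered aromatic ring with 1 hetero atom), on an aromatic carbon. Every measured step here bears on this position, and each was large, so the bicyclic group governs the read-out strongly. Compound 4 shares with compound 2 a six-membered aromatic ring of carbon only, and compound 2 gives 33 nM; compound 4 is expected to land in a similar region, meaning a step of an at least 40-fold higher number from compound 3 to compound 4 (1.60 log units; beyond the scatter). The estimate for compound 4 is 40 nM, within 4 nM to 400 nM.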

Compound 4, concentration for 50% growth inhibition: 346 nM
Estimate against measurement, compound 4: 8.7-fold (0.94 log units) below; the measured number falls inside the stated range.
By their numbers in this assay, from the lowest: compound 2; then compounds 4 and 1 (each within the scatter of the next). At a limit, below all of these: compound 3.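

Compound 3 stands at a limit and not at a number, and although the change to 1H-indazol-3-yl keeps the atoms and the counts of hydrogen-bond donors and acceptors, joining those atoms differently gives an at least 340-fold higher number from compound 3 to compound 4 (2.53 log units; beyond the scatter) in this assay: the limit of < 1 nM in this assay, at which 1 of the 4 values shown sits.

The earlier steps shown here altered only the six-membered ring of the bicyclic group, whereas 1H-indazol-3-yl in place of 1H-indol-3-yl alters the five-membered ring and gives a 10-fold higher number from compound 2 to compound 4 (1.02 log units; beyond the scatter), so a six-membered aromatic ring of carbon only does not by itself set the value. The remaining comparison, a 1.2-fold lower number from compound 1 to compound 4 (0.08 log units; within the scatter), lies within the scatter, so two groups built differently, one with its second nitrogen in the six-membered ring and the other with it in the five-membered ring, cannot be told apart in this assay.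

The compounds shown give no true number for compound 3, so the full size of its steps stays unknown. They also leave open whether a fluorine or an amino group on the six-membered ring of the bicyclic group of compound 3 would keep the value at that limit.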